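This account rests on a few compounds, and the source may have more. Where it says the series, first, only, none or still open, it means among the compounds named here.

Measured so far:
compound 1, `CCCCCCN(CCCCCSc1nc2ccccc2s1)C(=O)Nc1ccc(F)cc1F`: 4000 nM
compound 2, `CCCCCCN(CCOCCSc1nc2c[nH]cnc-2n1)C(=O)Nc1ccc(F)cc1F`: "not active" (no number reported)
compound 3, `CCCCCCCN(CCCCCSc1nc(O)c2ccccc2n1)C(=O)Nc1ccc(F)cc1F`: 4000 nM

In an assay on microsomes from liver for inhibition of sterol O-acyltransferase 1 (Rattus norvegicus) (a higher number here means a weaker inhibitor, a lower number a stronger inhibitor), compound 3 gives 4000 nM. That places it level with compound 1, which in this assay gives 4000 nM; the two values lie within the scatter of each other, so nothing separates them. Compound 2 is reported in this assay only as "not active" (no number reported), with no number behind it, so it sets no point on the scale.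

Compound 4, `CCCCCCCN(CCCCCSc1[nH]cnc2nncc1-2)C(=O)Nc1ccc(F)cc1F`, has not yet been measured in this assay. It differs from compound 3 in one place: a group of 9 heavy atoms (5 carbon, 4 nitrogen; one five-membered aromatic ring with 2 hetero atoms, one six-membered aromatic ring with 2 hetero atoms) in place of a group of 11 heavy atoms (8 carbon, 2 nitrogen, 1 oxygen; one six-membered aromatic ring of carbon only, one six-membered aromatic ring with 2 hetero atoms), on a sulfur. Going by the values given here, no step between measured compounds matches this change, so the size of the step can only be guessed. The nearest hint is compound 2, which also carries two nitrogen-containing aromatic rings on the sulfur and is reported without a number in this assay; compound 2 differs as well in the chain between the nitrogen and the sulfur, so the hint is loose. The step from compound 3 to compound 4 is expected to run toward weaker inhibition, beyond the scatter, a 2.0-fold higher number from compound 3 to compound 4 (0.30 log units; within the scatter). Compound 4 is therefore expected to give about 8000 nM in this assay, within the range 2000 nM to 40000 nM, with a real chance that only a limit is reported.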

Compound 4, half-maximal inhibitory concentration: 710 nM
The estimate for compound 4 lay 11-fold (1.05 log units) above the measured number, outside the stated range (below it).
By their numbers in this assay, from the lowest: compound 4; then compounds 1 and 3 (each within the scatter of the next).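

Within this assay, the group on the sulfur is the first place in this series where a single change gives a readable step: replacing 4-hydroxyquinazolin-2-yl with the group of one five-membered and one six-membered aromatic ring gives a 5.6-fold lower number from compound 3 to compound 4 (0.75 log units; beyond the scatter), a modest step beyond the scatter. The hydrogen-bond donor count, the acceptor count and the net charge stay the same across this change, while the heavy-atom count falls and the six-membered aromatic ring of carbon only gives way to a five-membered aromatic ring with hetero atoms, so this position tolerates a smaller group with more nitrogen without any loss. No measurement at hand accounts for the step.

A single pair cannot separate the contribution of the ring size from that of the added nitrogen atoms, and it cannot show whether the step carries over to other chains on the urea nitrogen, such as a longer chain. Also open, as far as these compounds go, is how the entering group responds to a substituent on its rings, for example a methyl group, an amine or a carboxylic acid.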